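Cyclopropyl for Trifluoromethyl on a Chloro-Bearing Core

A few compounds are considered here, and "the series" means these few. Any claim that something is new, unique, unknown or untested is made for them only; others in the source may bear on it.

Measured compounds:
compound 1, `N#Cc1c(N2CCC(c3ccccc3)CC2)ccn2c(CC(F)(F)F)nnc12`: 56 nM
compound 2, `N#Cc1c(N2CCC(c3ccccc3)CC2)ccn2c(CC3CC3)nnc12`: 74 nM
compound 3, `FC(F)(F)Cc1nnc2c(Cl)c(N3CCC(c4ccccc4)CC3)ccn12`: 55 nM

These three numbers come from a functional assay on CHO cells for positive allosteric modulation of metabotropic glutamate receptor 2 (Homo sapiens), read by GTPgammaS binding, with a stated time of 30 min; on this read-out lower numbers stand for an effect already at smaller amounts and higher numbers for an effect only at larger amounts of compound. Compound 1 and compound 2 share one core and differ by cyclopropyl in place of trifluoromethyl on a saturated chain carbon bound to an aromatic carbon; this change gave a 1.3-fold higher number from compound 1 to compound 2 (0.12 log units; within the scatter). Compound 3 has a different core: it differs from compound 1 by chloro in place of cyano on an aromatic carbon, and that difference gave a 1.0-fold lower number from compound 1 to compound 3 (0.01 log units; within the scatter).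

Compound 4, `Clc1c(N2CCC(c3ccccc3)CC2)ccn2c(CC3CC3)nnc12`, has not yet been measured in this assay. Among the measured compounds shown here, it differs from compound 3 by cyclopropyl in place of trifluoromethyl on a saturated chain carbon bound to an aromatic carbon, which is the same change as the one from compound 1 to compound 2, at the same place, now made on the core of compound 3. The step is expected to resemble the earlier one because a 1.0-fold lower number from compound 1 to compound 3 (0.01 log units; within the scatter) lay within the scatter, so the two cores do not appear to respond very differently; the expected step is a 1.3-fold higher number from compound 3 to compound 4 (0.10 log units; within the scatter). On that basis compound 4 is estimated at 70 nM, with a likely range from 35 nM to 140 nM.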

Compound 4, half-maximal effective concentration: 102 nM
Compound 4: the middle estimate sits 1.5-fold (0.16 log units) below what was measured, and the stated range covers the measured number.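

In this assay the swap of cyclopropyl for trifluoromethyl on the core of compound 3 gave a 1.9-fold higher number from compound 3 to compound 4 (0.27 log units; within the scatter), and this step agrees with the one on the core of compound 1: the same change on two cores in this assay, a 1.3-fold higher number (0.12 log units; within the scatter) from compound 1 to compound 2 and a 1.9-fold higher number (0.27 log units; within the scatter) from compound 3 to compound 4, 1.4-fold (0.15 log units) apart, within the scatter of two such steps. Chloro in place of cyano on an aromatic carbon gave a 1.4-fold higher number from compound 2 to compound 4 (0.14 log units; within the scatter), and that change likewise reads alike on the two cores: the same change on two cores in this assay, a 1.0-fold lower number (0.01 log units; within the scatter) from compound 1 to compound 3 and a 1.4-fold higher number (0.14 log units; within the scatter) from compound 2 to compound 4, 1.4-fold (0.15 log units) apart, within the scatter of two such steps. Each step lies within the scatter, so these four compounds show that both changes carried from one core to the other without a detectable difference, but they do not show that either change has a real effect or that the agreement would hold on any further core.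

The compounds shown leave open how a longer chain or an amine on the saturated chain carbon would behave, or a methoxy group or a carboxylic acid on the aromatic carbon. They also leave open whether a step large enough to stand beyond the scatter would carry between these cores in the same way.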